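Compound 4: trifluoromethoxy in place of isopropoxy

This account rests on a few compounds, and the source may have more. Where it says the series, first, only, none or still open, it means among the compounds named here.

In an ADME assay on BJ cells (Homo sapiens) for cytotoxicity, read by luminescence, with a stated time of 72 h (on this read-out higher numbers stand for an effect only at larger amounts of compound and lower numbers for an effect already at smaller amounts), compound 3 (`CCOC(=O)c1c(-c2cccc(OC)c2)[nH]c2cc(OC(C)C)ccc2c1=O`) reads > 21500 nM as a limit and not a number. Compound 1 (`CCOC(=O)c1c(-c2cccc(OC)c2)[nH]c2cc(OC)ccc2c1=O`) reads > 21500 nM as a limit too. Compound 2 (`CCOC(=O)c1c(-c2cccc(-c3ccccc3)c2)[nH]c2cc(OC(C)C)ccc2c1=O`) reads > 21500 nM as a limit too. Compound 3 thus stands at the limit of > 21500 nM in this assay, at which 3 of the 3 values shown sit, and no number is available yet.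

Compound 4 (`CCOC(=O)c1c(-c2cccc(OC)c2)[nH]c2cc(OC(F)(F)F)ccc2c1=O`) carries trifluoromethyl in place of isopropyl on an oxygen on an aromatic ring. The step that the two limits leave unreadable from compound 1 to compound 3 on the same oxygen and the step that the two limits leave unreadable from compound 2 to compound 3 elsewhere bear on it and neither has a readable size. No step beyond the scatter is therefore expected in this assay and no direction can be given. The estimated step is a step that the limit leaves unreadable from compound 3 to compound 4 and it is expected to remain small. For compound 4 the estimate is 25000 nM with an expected range of 12000 nM to 50000 nM and a report as a limit is the likeliest outcome.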

Compound 4, half-maximal effective concentration: > 21500 nM
Compound 4: only a limit was reported (the forecaster's own chance of this, stated with the estimate: 85%); the middle value lies beyond the limit too.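

In this assay, no step can be read from compound 1 or compound 3 to compound 4, as all three stand only as limits: the limit of > 21500 nM in this assay, at which 4 of the 4 values shown sit. The compounds shown leave open whether any change on the shared core would give a numerical value.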